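Naphthyloxyacetyl hydrazones: bromophenyl in place of nitrophenyl

A few compounds are considered here, and "the series" means these few. Any claim that something is new, unique, unknown or untested is made for them only; others in the source may bear on it.

Two hydrazones of the shared core have been measured in an ADME assay on HEL cells (Homo sapiens) for cytotoxicity; a higher number here means that more compound is tolerated, a lower number that less compound is tolerated. Compound 1 `C/C(=N\NC(=O)COc1cccc2ccccc12)c1cccc([N+](=O)[O-])c1` gives 20 ug/mL in this assay. Compound 2 `O=C(COc1cccc2ccccc12)N/N=C/C=C/c1ccccc1` gives 100 ug/mL in this assay. Going by the values given here, compound 1 therefore stands at the lower of the two numbers, and compound 2 sits beyond the scatter above it; the two structures differ in more than one place, so no single step can be drawn between them.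

Compound 3 `C/C(=N\NC(=O)COc1cccc2ccccc12)c1ccc(Br)cc1` has not yet been measured in this assay. It differs from compound 1 as follows: 4-bromophenyl in place of 3-nitrophenyl on a carbon with a double bond to nitrogen. Among the compounds with values here, no measured pair shares this change, so nothing in the data gives its size directly. Within the data shown here, since compound 1 gives 20 ug/mL and the aryl group is the only change, the step of a 1.5-fold higher number from compound 1 to compound 3 (0.18 log units; within the scatter) is expected to be small, not clearly beyond the scatter, and if anything upward. For compound 3 the estimate in this assay is 30 ug/mL, in a range from 10 ug/mL to 100 ug/mL.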

Compound 3, minimum cytotoxic concentration: 20 ug/mL
Compound 3: the middle estimate sits 1.5-fold (0.18 log units) above what was measured; the measured number falls inside the stated range.
By their numbers in this assay, from the lowest: compounds 1 and 3 (each within the scatter of the next); then compound 2.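

Going by these compounds alone, the first step in one place within this assay is 4-bromophenyl in place of 3-nitrophenyl on a carbon with a double bond to nitrogen, and it reads no change at the digits printed from compound 1 to compound 3 (within the scatter). At this place, then, the aryl group can lose the nitro group and take a bromine without a change that can be told from the scatter, even though the two groups differ in heavy atoms and hydrogen-bond acceptors. Nothing in hand gives a reason for this result.

This single step changes both the substituent and its ring position, so 3-bromophenyl and 4-nitrophenyl would be needed to separate the two. Also open, on these data alone, is whether an aryl group carrying an amine or a carboxylic acid, or an ethyl chain on the same carbon, would move the number beyond the scatter.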